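Notes on a chain-carbon methyl and cytotoxicity

A few compounds are considered here, and "the series" means these few. Any claim that something is new, unique, unknown or untested is made for them only; others in the source may bear on it.

Compound 1 `CCCNc1nc(C(C)c2c(F)cccc2F)c(C)c(=O)[nH]1`: 35000 nM
Compound 2 `CCN(C)c1nc(Cc2c(F)cccc2F)c(C)c(=O)[nH]1`: > 85000 nM
Compound 3 `Cc1c(Cc2c(F)cccc2F)nc(N(C)C(C)C)[nH]c1=O`: 79000 nM

All three values come from an ADME assay on MT4 cells (Homo sapiens) for cytotoxicity, read by MTT assay, with a stated time of 4 days; on this read-out higher numbers stand for lower toxicity in this test and lower numbers for higher toxicity in this test. Compound 2 stands at the limit of > 85000 nM in this assay, at which 1 of the 3 values shown sits, so its entry is a limit and not a number.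

The change to compound 4 `CCN(C)c1nc(C(C)c2c(F)cccc2F)c(C)c(=O)[nH]1` is methyl in place of hydrogen on a saturated chain carbon bound to two aromatic carbons, a methyl in place of hydrogen on a saturated chain carbon bound to two aromatic carbons. Going by the values given here, the only measured step, an at least 1.0-fold lower number from compound 2 to compound 3 (0.03 log units; that floor lies within the scatter), places a methyl on a different carbon, a saturated chain carbon bound to a nitrogen on an aromatic ring and a saturated chain carbon. It therefore bears only loosely on this change.

Closer evidence is compound 1, which carries the methyl on the same carbon but has a different amine chain, and gives 35000 nM. On that value, a lower number is expected in this assay, though the size is uncertain while compound 2 has only a limit. The expected change is an at least 1.8-fold lower number from compound 2 to compound 4 (0.27 log units; that floor lies within the scatter). For compound 4 the estimated value is 45000 nM, with an expected range of 20000 nM to 95000 nM.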

Compound 4, half-maximal cytotoxic concentration: 81000 nM
Compound 4: middle estimate off by 1.8-fold (0.26 log units), on the low side; the range from low to high includes it.
By their numbers in this assay, from the lowest: compound 1; then compounds 3 and 4 (each within the scatter of the next). At a limit, above all of these: compound 2.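

On the saturated chain carbon bound to two aromatic carbons, the methyl now has a direct reading in this assay, an at least 1.0-fold lower number from compound 2 to compound 4 (0.02 log units; that floor lies within the scatter), and this floor gives no change that can be told from the scatter. Compound 2 remains a limit and not a number: the limit of > 85000 nM in this assay, at which 1 of the 4 values shown sits. With the methyl held on that carbon, ethyl(methyl)amino in place of propylamino on an aromatic carbon gives a 2.3-fold higher number from compound 1 to compound 4 (0.36 log units; beyond the scatter), so within this pair the difference goes with the amine chain and not with the methyl.

As far as these compounds go, the true size of the methyl step stays open while one end of it is a limit. Also open, from the compounds shown here alone, is how this assay responds to an ethyl or a hydroxyl on that carbon, or to a pyrrolidine in place of ethyl(methyl)amino.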